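A few compounds are considered here, and "the series" means these few. Any claim that something is new, unique, unknown or untested is made for them only; others in the source may bear on it.

Working notes on the series in a toxicity assay on THP-1 cells (Homo sapiens) for inhibition; on this read-out higher numbers stand for lower toxicity in this test and lower numbers for higher toxicity in this test. Compound 1, `Cn1c(-c2cccc(C#N)c2)cnc1NC(=O)c1ccc(F)cc1`, is reported only as a limit here, > 100000 nM. Compound 2, `COc1ccc(-c2cnc(NC(=O)C3CCCCC3)n2C)cc1`, likewise gives only a limit in this assay, > 100000 nM, so its standing is known as a limit and not as a number. Compound 3, `COc1ccc(CNC(=O)NC(=O)c2ccc(F)cc2)cc1`, is also recorded as a limit in this assay, > 50000 nM. Going by the values given here, two of the three entries share the same limit, (the limit of > 100000 nM in this assay, at which 2 of the 3 values shown sit), and the third sits at the limit of > 50000 nM in this assay, at which 1 of the 3 values shown sits; no compound of the set returns a number, and no pair of measured compounds differs in a single place, so no measured step can be read within the set.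

Compound 4, `COc1ccc(-c2cnc(NC(=O)c3cccnc3)n2C)cc1`, is not yet measured in this assay. Relative to compound 2 it carries one change: pyridin-3-yl in place of cyclohexyl on a carbonyl carbon. Among the compounds with values here, with compound 2 at a limit and no measured step to build on, the expected step in this assay is a number no higher from compound 2 to compound 4 (the limit leaves the size open), none beyond the scatter, and the most probable outcome for compound 4 is again a limit rather than a number. For compound 4 in this assay the estimate is 100000 nM, with a range from 50000 nM to 200000 nM.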

Compound 4, half-maximal cytotoxic concentration: > 100000 nM
Compound 4: only a limit was reported (the forecaster's own chance of this, stated with the estimate: 80%); the middle value sits exactly at the limit.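

Compound 2 and compound 4 are both reported only as limits in this assay, so the step of pyridin-3-yl in place of cyclohexyl on a carbonyl carbon cannot be read. The compounds shown leave open whether any of them would return a number in this assay, and how pyridin-3-yl and cyclohexyl compare there: the limit of > 100000 nM in this assay, at which 3 of the 4 values shown sit.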